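The compounds below may be only part of what the source reports. "The series", "measured", "known", "first", "only" and "open" are said of these compounds alone.

Measured so far in a functional assay on MCF7 cells (Homo sapiens) for inhibition, read by MTT assay, with a stated time of 48 h; a lower number here means a stronger inhibitor, a higher number a weaker inhibitor:
compound 1 `C=C1CN(C)N(c2ccc(Cl)cc2)C1=O` — 45200 nM
compound 2 `C=C1CN(C)N(c2ccccc2)C1=O` — 56000 nM
compound 3 `C=C1CN(C)N(c2ccc(Br)cc2)C1=O` — 43800 nM

Compound 2 sits with the other two within the scatter: a 1.2-fold higher number from compound 1 to compound 2 (0.09 log units; within the scatter) and a 1.3-fold lower number from compound 2 to compound 3 (0.11 log units; within the scatter), and likewise a 1.0-fold lower number from compound 1 to compound 3 (0.01 log units; within the scatter). On these numbers nothing separates the three compounds, so compound 2 is as good a starting point as any.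

Compound 4 `C=C1C(=O)N(c2ccccc2)N(C)C1CC` differs from compound 2 by ethyl in place of hydrogen on a saturated ring carbon. None of the three measured steps touches this position; all three vary the group on the aromatic ring, and all three lie within the scatter. Going by the values given here, there is therefore no measured step that bears on an ethyl entering at a saturated ring carbon, and no basis for expecting a shift in this assay in either direction beyond the scatter.

The expectation for compound 4 is accordingly a number close to that of compound 2, no change at the digits printed from compound 2 to compound 4 (within the scatter), with a wide range to cover the untested position.

Compound 4 is estimated at 56000 nM, range 20000 nM to 160000 nM.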

Compound 4, half-maximal inhibitory concentration: 185000 nM
Compound 4: middle estimate off by 3.3-fold (0.52 log units), on the low side; measured number outside the range, above it.
By their numbers in this assay, from the lowest: compounds 3, 1 and 2 (each within the scatter of the next); then compound 4.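

In this assay, going by these compounds alone, the saturated ring carbon next to the ring nitrogen is the first place where a change moves the number beyond the scatter: ethyl in place of hydrogen gives a 3.3-fold higher number from compound 2 to compound 4 (0.52 log units; beyond the scatter). The changes on the aromatic ring among compound 1, compound 2 and compound 3 all stayed within the scatter, so this ring carbon responds where that aromatic position did not, and the ethyl step runs toward a weaker inhibitor. Nothing available explains this shift.

A single step leaves open whether the weakening is specific to ethyl or extends to other groups at this carbon, such as methyl, a longer chain like propyl, a hydroxyl or an amine. Going by these compounds, it is also open whether the ethyl step keeps its size with chloro or bromo on the aromatic ring.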